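The source may hold more compounds than are shown below. What is called first, only, known or untested is meant among the compounds shown, and "the series" means these compounds.

Going by the values given here, compound 2 `Cc1ccc(NC(=O)NC2CCN(c3ncnc4[nH]ncc34)CC2)cc1` gives 4710 nM in an assay on isolated protein for inhibition of serine/threonine-protein kinase PAK 1 (Homo sapiens), read by ADP-Glo, with a stated time of 40 min (a higher number here means a weaker inhibitor, a lower number a stronger inhibitor), and holds the lowest of the two numbers measured so far; compound 1 `O=C(NC1CCN(c2ncnc3[nH]ncc23)CC1)c1ccccc1Cl` gives 5240 nM in this assay, and the step of a 1.1-fold lower number from compound 1 to compound 2 (0.05 log units; within the scatter) lies within the scatter. Compound 3 `O=C(Nc1cccc(Cl)c1)NC1CCN(c2ncnc3[nH]ncc23)CC1` carries 3-chlorophenyl in place of 4-methylphenyl on an amide-type nitrogen. Among the compounds with values here, no measured step touches this ring; the only step known, from compound 1 to compound 2, was small and sits on the carbonyl carbon. For compound 3 the step of a 1.0-fold lower number from compound 2 to compound 3 (0.02 log units; within the scatter) is therefore expected to stay within the scatter. Compound 3 is estimated at 4500 nM, between 1500 nM and 13000 nM.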

Compound 3, half-maximal inhibitory concentration: 1240 nM
The estimate for compound 3 lay 3.6-fold (0.56 log units) above the measured number; measured number outside the range, below it.
By their numbers in this assay, from the lowest: compound 3; then compounds 2 and 1 (each within the scatter of the next).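

The group on the amide-type nitrogen proved able to move the number in this assay, which the earlier step, within the scatter, had not shown: 3-chlorophenyl in place of 4-methylphenyl gives a 3.8-fold lower number from compound 2 to compound 3 (0.58 log units; beyond the scatter). Placing (3-chlorophenyl)amino on the carbonyl carbon in place of 2-chlorophenyl gives a 4.2-fold lower number from compound 1 to compound 3 (0.63 log units; beyond the scatter). No evidence at hand bears on this result.

On these data alone, whether the chlorine itself or where it sits on the ring carries the step stays open. So does the outcome with a methoxy group or a nitrile on that ring.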